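Swapping the diamine side chain for an amino alcohol

The source may report more compounds than this note shows. Statements on the series, on what has been measured and on what is new or still open speak of the compounds shown alone.

Of the compounds shown here, three sharing one core have been tested in an assay on HeLa cells for inhibition of sphingosine-1-phosphate transporter SPNS2 (Mus musculus), read by LC-MS, tested at 2 uM; on this read-out lower numbers stand for less inhibition and higher numbers for more inhibition at the one concentration tested (going by the name of the read-out). Compound 1 `CCCCCCCCCCc1ccc(-c2noc([C@H]3CCCN3)n2)cc1` gives 12%, compound 2 `CCCCCCCCCCc1ccc(-c2noc(CN3CCNCC3)n2)cc1` gives 19%, and compound 3 `CCCCCCCCCCc1ccc(-c2noc([C@@H](N)CCCCN)n2)cc1` gives 43%. Compound 3 stands highest of the three numbers: the step of a number 31 percentage points higher from compound 1 to compound 3 (beyond the scatter) and the step of a number 24 percentage points higher from compound 2 to compound 3 (beyond the scatter) both lie beyond the scatter, while the step of a number 7 percentage points higher from compound 1 to compound 2 (within the scatter) does not.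

Compound 4 `CCCCCCCCCCc1ccc(-c2noc(CC(O)CNCC)n2)cc1` has not yet been measured. Compared with compound 3 it differs in one place: 3-(ethylamino)-2-hydroxypropyl in place of 1,5-diaminopentyl on an aromatic carbon. The group that leaves carries two nitrogens with no ring; the group that enters also has no ring, keeps the same count of hydrogen-bond donors and acceptors, but holds one nitrogen and one oxygen in place of two nitrogens.

Both measured steps that end at compound 3 point the same way: the 1,5-diaminopentyl group gave the highest inhibition seen so far. Compound 4 keeps an open chain but gives up one of the two nitrogens, so the expectation is a step of a number 18 percentage points lower from compound 3 to compound 4 (beyond the scatter) in this assay, that is a fall of modest size. For compound 4 the estimated inhibition is 25%, within a range from 8% to 45%.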

Compound 4, a percentage reported as inhibition, at one concentration (the size of the read-out at that concentration, not a potency): 5%
For compound 4 the middle estimate is 20 percentage points above the measured one; the whole stated range lies above it.
By their numbers in this assay, from the lowest: compounds 4, 1 and 2 (each within the scatter of the next, the first and the last beyond it); then compound 3.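

In this assay, the step of a number 38 percentage points lower from compound 3 to compound 4 (beyond the scatter) shows that the counts alone do not settle the outcome at this position: 3-(ethylamino)-2-hydroxypropyl matches 1,5-diaminopentyl in heavy atoms, hydrogen-bond donors and acceptors, and the absence of a ring, yet the inhibition does not hold up. An open chain is not enough by itself either, as the open-chain 3-(ethylamino)-2-hydroxypropyl group shows in the step of a number 14 percentage points lower from compound 2 to compound 4 (beyond the scatter), set against a group with a ring, and in the step of a number 7 percentage points lower from compound 1 to compound 4 (within the scatter), set against pyrrolidin-2-yl. Among the four groups, 1,5-diaminopentyl alone stands clear of the rest on this aromatic carbon, so what matters here is something more specific to that group than its size or its lack of a ring.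

Nothing available explains the difference between these side chains. Still open, as far as these compounds go, is whether the oxygen in place of a nitrogen or the different layout of the chain accounts for the fall, and an open chain with an amine in place of the hydroxyl of 3-(ethylamino)-2-hydroxypropyl would help separate the two.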